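The source may hold more compounds than are shown below. What is called first, only, known or untested is meant among the compounds shown, and "the series" means these compounds.

Two compounds have been measured so far:
compound 1, `CC(C)(C)c1ccc(Oc2ccc3c(NCCCNCc4ccco4)ccnc3c2)cc1`, with 14500 nM in a physicochemical assay for solubility, with a stated time of 18 h, at pH 7.4; on this read-out lower numbers stand for lower solubility and higher numbers for higher solubility;
compound 2, `COc1cccc(CNCCCNc2ccnc3cc(-c4ccc(C(C)(C)C)cc4)ccc23)c1O`, with 32000 nM in this assay.

Of these two numbers compound 1 has the lower one, and the number for compound 2 stands higher by a gap beyond the usual scatter of the measurement. Compound 3, `COc1ccccc1Oc1ccc2c(NCCCNCc3ccco3)ccnc2c1`, has not yet been measured. It differs from compound 1 in one place: 2-methoxyphenyl in place of 4-(tert-butyl)phenyl on an oxygen on an aromatic ring. Going by the values given here, no pair of measured compounds shows this particular change, so nothing measured here tells how large a move it brings; the expectation rests on the starting point of compound 1 alone and is held loosely. In this assay an upward move is expected, somewhat beyond the scatter: a 2.8-fold higher number from compound 1 to compound 3 (0.44 log units; beyond the scatter). Compound 3 is therefore estimated at 40000 nM, within a range from 12000 nM to 130000 nM.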

Compound 3, solubility: 14500 nM
Compound 3: middle estimate off by 2.8-fold (0.44 log units), on the high side, within the range that was stated.
By their numbers in this assay, from the lowest: compounds 1 and 3 (each within the scatter of the next); then compound 2.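

In this assay, putting 2-methoxyphenyl in place of 4-(tert-butyl)phenyl on an oxygen on an aromatic ring gives no change at the digits printed from compound 1 to compound 3 (within the scatter). Going by these compounds alone, this is the first direct reading at this position, and it shows that the group there can be exchanged without a shift in this read-out, even though the group leaving has 10 heavy atoms, all carbon, and no hydrogen-bond acceptor, while the group entering has 8 heavy atoms, one of them oxygen, and 1 hydrogen-bond acceptor. No measurement here explains why the two compounds read alike.

This is one exchange on one compound, so it sets no general rule for this position. On these data alone, whether a group carrying an amine or a carboxylic acid, or a longer chain on the same oxygen, would also leave the number in place remains open.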